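Tetrazolylmethyl in place of cyanoimino ring on lactam series

A few compounds are considered here, and "the series" means these few. Any claim that something is new, unique, unknown or untested is made for them only; others in the source may bear on it.

Measured in an assay on CHO cells for displacement of a labelled ligand from prostaglandin E2 receptor EP3 subtype (Homo sapiens), read by radioligand binding; on this read-out higher numbers stand for weaker inhibition and lower numbers for stronger inhibition:
compound 1 `CCn1ncc2c(F)cc(-c3ccc(C(CC)(CC)c4nnc(C)[nH]4)c(=O)[nH]3)cc21` gives 34 nM
compound 2 `CCn1ncc2c(C)cc(-c3ccc([C@@]4(C)CCNC4=O)c(=O)[nH]3)cc21` gives 5 nM
compound 3 `CC(C)C(c1ccc(-c2ccc3cccc(F)c3c2)[nH]c1=O)N1CCN/C1=N\C#N` gives 23 nM

Compound 3 has the second highest of the three numbers in this assay. Its value and that of compound 1 lie within the usual scatter of each other, so no order between the two is claimed. Compound 2 gives a clearly lower number than compound 3, beyond the scatter.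

Compound 4 `CC(C)C(Cc1nnn[nH]1)c1ccc(-c2ccc3cccc(F)c3c2)[nH]c1=O` is the next entry. It differs from compound 3 in one place: a group of 6 heavy atoms (2 carbon, 4 nitrogen; one five-membered aromatic ring with 4 hetero atoms) in place of a group of 8 heavy atoms (4 carbon, 4 nitrogen; one five-membered non-aromatic ring with 2 hetero atoms), on a saturated chain carbon bound to an aromatic carbon and a saturated chain carbon. Among the compounds with values here, no pair of measured compounds shows this change, so no measured step guides it. The expectation in this assay is a small shift toward a higher number, of a size close to the edge of the scatter. Compound 4 is expected to give about 40 nM, within 10 nM to 160 nM, which corresponds to an estimated step of a 1.7-fold higher number from compound 3 to compound 4 (0.24 log units; within the scatter).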

Compound 4, inhibition constant: 34 nM
Compound 4: the middle estimate sits 1.2-fold (0.07 log units) above what was measured; the measured number falls inside the stated range.
By their numbers in this assay, from the lowest: compound 2; then compounds 3, 1 and 4 (each within the scatter of the next).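

In this assay, (1H-tetrazol-5-yl)methyl in place of the cyanoimino ring gives a 1.5-fold higher number from compound 3 to compound 4 (0.17 log units; within the scatter), so no order between the two is claimed. On a saturated chain carbon bound to an aromatic carbon and a saturated chain carbon, a five-membered aromatic ring and a five-membered non-aromatic ring therefore read alike within the scatter. No supporting measurement bears on this result.

Still open, going by these compounds, is how a carboxylic acid or an amine would read in place of the (1H-tetrazol-5-yl)methyl group. Also open, on these data alone, is whether the same change would read alike on the cores of compound 1 and compound 2.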